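A few compounds are considered here, and "the series" means these few. Any claim that something is new, unique, unknown or untested is made for them only; others in the source may bear on it.

Three compounds that share one core were tested in a functional assay on the whole organism (strain Wistar) for inhibition, with Rattus norvegicus as the target, read by paw edema, with stated times of 60 min and 6 h, at a dose of 100 mg/kg by the oral route; on this read-out higher numbers stand for more inhibition at the one dose given (going by the name of the read-out) and lower numbers for less inhibition. Compound 1 `COc1cc2c(cc1OC)C(CC(=O)N(C)C)CC2` gives 33.3% in this assay, which puts it second highest among the three measured numbers. Compound 2 `CCNC(=O)CC1CCc2cc(OC)c(OC)cc21` gives 20.4% and compound 3 `COc1cc2c(cc1OC)C(CC(=O)NC1CCCCC1)CC2` gives 48.2%. The three differ only in the group on the carbonyl carbon: a number 12.9 percentage points lower from compound 1 to compound 2 (beyond the scatter), while a number 14.9 percentage points higher from compound 1 to compound 3 (beyond the scatter), and a number 27.8 percentage points higher from compound 2 to compound 3 (beyond the scatter).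

Compound 4 `COc1cc2c(cc1OC)C(CC(=O)N1CCCC1)CC2` has not yet been measured. It differs from compound 1 in this way: pyrrolidin-1-yl in place of dimethylamino on a carbonyl carbon. Both compound 1 and compound 4 carry a group with no hydrogen on the nitrogen, and pyrrolidin-1-yl brings more carbon than dimethylamino, though less than cyclohexylamino. Among the measured compounds, the larger group on the carbonyl carbon went with the higher number, and compound 2, which carries the smallest group, gives the lowest of the three. Because compound 3 gives 48.2% with the largest group, compound 4 is expected to show a step of a number 6.7 percentage points higher from compound 1 to compound 4 (within the scatter), small enough that it may not exceed the usual scatter. The estimate for compound 4 in this assay is 40%, within a range from 25% to 55%.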

Compound 4, a percentage reported as inhibition, in the whole organism at one dose (the size of the read-out at that dose, not a potency): 22.2%
Beside the measured number, compound 4's estimate is 17.8 percentage points above it; the measured number lies below the stated range.
By their numbers in this assay, from the lowest: compounds 2 and 4 (each within the scatter of the next); then compound 1; then compound 3.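

At this place, on a carbonyl carbon, the size of the group no longer follows the read-out in this assay: pyrrolidin-1-yl holds more heavy atoms than dimethylamino, yet the change gives a number 11.1 percentage points lower from compound 1 to compound 4 (beyond the scatter), so compound 4 goes against the link between larger group and higher number seen in compounds 1, 2 and 3. Measured against cyclohexylamino, the same group gives a number 26 percentage points lower from compound 3 to compound 4 (beyond the scatter), and against ethylamino it gives a number 1.8 percentage points higher from compound 2 to compound 4 (within the scatter), so carrying a ring does not by itself go with the higher number, and compound 2, which keeps the amide hydrogen, cannot be told apart from compound 4, which lacks it. The data at hand offer no explanation for these steps.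

Cyclopentylamino would show whether a five-membered ring gives a higher number when it is joined through a nitrogen that keeps its hydrogen, and N-methylcyclohexylamino would show whether the number of compound 3 survives loss of that hydrogen. Piperidin-1-yl and morpholin-4-yl would show whether the result for compound 4 holds for other rings closed through the nitrogen.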